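A single exchange on the carbonyl carbon of compound 2

The compounds below may be only part of what the source reports. "The series", "measured", "known", "first", "only" and "open" are said of these compounds alone.

- compound 1 (`C[Se]c1ccc(N(C)c2nc(C3CC3)nc3ccccc23)cc1`): 21 nM
- compound 2 (`COc1ccc(N(C)c2nc(C)nc3ccccc23)cc1C(=O)OCC[Se]C#N`): 2390 nM
- compound 3 (`Cc1nc(N(C)c2ccc([Se]C#N)c(C)c2)c2ccccc2n1`): 17 nM

In a functional assay on RKO cells (Homo sapiens) for inhibition, read by MTT assay, with a stated time of 48 h (a lower number here means a stronger inhibitor, a higher number a weaker inhibitor), compound 2 gives 2390 nM and holds the highest of the three numbers. Its gaps to compound 1 and compound 3 both lie beyond the scatter, which makes it the weakest inhibitor of the three. Compound 4 (`COc1ccc(N(C)c2nc(C)nc3ccccc23)cc1C(=O)NCC[Se]C#N`) has not yet been measured. It differs from compound 2 in one place (a group of 6 heavy atoms (3 carbon, 2 nitrogen, 1 selenium; no ring) in place of a group of 6 heavy atoms (3 carbon, 1 nitrogen, 1 oxygen, 1 selenium; no ring), on a carbonyl carbon), on a carbonyl carbon. Among the measured compounds shown here, no measured pair shows this exchange, so the data give no direct size for it. Compound 1 and compound 3 carry no such group on a carbonyl carbon, which leaves compound 2 (2390 nM) as the only close reference. The expected change is therefore none beyond the scatter, in either direction (a 1.2-fold lower number from compound 2 to compound 4 (0.08 log units; within the scatter)). For compound 4 the estimated value is 2000 nM, with an expected range from 400 nM to 10000 nM.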

Compound 4, half-maximal inhibitory concentration: 1170 nM
The estimate for compound 4 lay 1.7-fold (0.23 log units) above the measured number, and the stated range covers the measured number.
By their numbers in this assay, from the lowest: compounds 3 and 1 (each within the scatter of the next); then compound 4; then compound 2.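

In this assay, the exchange on the carbonyl carbon now has a measured size: a 2.0-fold lower number from compound 2 to compound 4 (0.31 log units; beyond the scatter), a modest step. Until now this position had a single measured occupant, whereas this pair shows that the number responds when a group with 1 hydrogen-bond donor and 1 hydrogen-bond acceptor replaces one with 0 hydrogen-bond donors and 2 hydrogen-bond acceptors, with the rest of the molecule unchanged. Nothing measured here accounts for the step.

The compounds shown leave open whether a carboxylic acid on this carbonyl carbon, or a longer chain in place of the one carried here, would move the number further. They also leave open whether the same exchange gives a step of similar size on another core.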